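From Thiophen-2-yl to Phenyl at the Assay Limit

A few compounds are considered here, and "the series" means these few. Any claim that something is new, unique, unknown or untested is made for them only; others in the source may bear on it.

Measured in a functional assay on HCT-116 cells (Homo sapiens), read by MTT assay, with a stated time of 72 h; on this read-out lower numbers stand for stronger inhibition and higher numbers for weaker inhibition:
Compound 1 `CSc1ncnc2c1c(-c1ccccc1)cn2[C@@H]1O[C@H](CO)[C@@H](O)[C@H]1O`: > 20000 nM, a limit
Compound 2 `CNc1ncnc2c1c(-c1ccoc1)cn2[C@@H]1O[C@H](CO)[C@@H](O)[C@H]1O`: > 20000 nM, a limit
Compound 3 `CNc1ncnc2c1c(-c1cccs1)cn2[C@@H]1O[C@H](CO)[C@@H](O)[C@H]1O`: > 20000 nM, a limit

Compound 3 has no number on this read-out, only the limit > 20000 nM. The other two compounds are also known only as limits, so none of the three can be ranked against another. The evidence so far is the limit of > 20000 nM in this assay, at which 3 of the 3 values shown sit.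

The next compound, compound 4 `CNc1ncnc2c1c(-c1ccccc1)cn2[C@@H]1O[C@H](CO)[C@@H](O)[C@H]1O`, differs from compound 3 by phenyl in place of thiophen-2-yl on an aromatic carbon. In words, this is phenyl in place of thiophen-2-yl on an aromatic carbon.

For the measured compounds named here, only one measured step swaps one aromatic ring for another on this carbon, and it gives no size: a step that the two limits leave unreadable from compound 2 to compound 3. Compound 1 also carries phenyl on this carbon, and its result is the limit > 20000 nM. Nothing measured therefore points to a gain in this assay, and no step beyond the scatter is expected in either direction. The expected step is a step that the limit leaves unreadable from compound 3 to compound 4, and it is a rough estimate because one end of it rests on a limit. The estimate for compound 4 is 30000 nM, with an expected range from 10000 nM to 60000 nM.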

Compound 4, half-maximal inhibitory concentration: > 20000 nM
Compound 4 ended at the assay's limit (the forecaster's own chance of this, stated with the estimate: 85%); the middle value is on the limit's open side.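

In this assay compound 4 gives > 20000 nM, a limit. For the compounds shown here, no step between compound 4 and compound 1, compound 2 or compound 3 can be read, and the evidence remains: the limit of > 20000 nM in this assay, at which 4 of the 4 values shown sit. The compounds shown leave open whether phenyl, thiophen-2-yl or furan-3-yl, or methylamino or methylsulfanyl, differ at all in this assay.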